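The source may hold more compounds than are shown below. What is called first, only, known or untested is meant among the compounds shown, and "the series" means these compounds.

For the measured compounds named here, compound 2 `Cn1ncc2cc(-c3cnccc3/C=C/C(=O)O)ccc21` gives the lower of the two numbers so far in an assay on a protein complex for inhibition of CDK8/Cyclin C (Homo sapiens), with a stated time of 1 h (a higher number here means a weaker inhibitor, a lower number a stronger inhibitor), at 34.6 nM; compound 1 `CCOC(=O)/C=C/c1ccncc1-c1ccc2c(cnn2C)c1` gives 102 nM, and the one measured step, a 2.9-fold lower number from compound 1 to compound 2 (0.47 log units; beyond the scatter), came with hydrogen in place of ethyl on an oxygen next to a carbonyl group. Compound 3 `CNC(=O)/C=C/c1ccncc1-c1ccc2c(cnn2C)c1` is not yet measured; it carries methylamino in place of hydroxy on a carbonyl carbon. Going by the values given here, no measured step exchanges a hydroxy for a methylamino, so the earlier change at the same carbonyl is only a rough guide. Compound 3 is expected near 60 nM, within 20 nM to 180 nM. For compound 3 this means an expected step of a 1.7-fold higher number from compound 2 to compound 3 (0.24 log units; within the scatter).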

Compound 3, half-maximal inhibitory concentration: 86.7 nM
Beside the measured number, compound 3's estimate is 1.4-fold (0.16 log units) below it; the range from low to high includes it.
By their numbers in this assay, from the lowest: compound 2; then compounds 3 and 1 (each within the scatter of the next).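

On this carbonyl carbon, methylamino in place of hydroxy gives a 2.5-fold higher number from compound 2 to compound 3 (0.40 log units; beyond the scatter), the second step at this carbon in which losing the hydroxy goes with a higher number. Methylamino in place of ethoxy gives a 1.2-fold lower number from compound 1 to compound 3 (0.07 log units; within the scatter), so compound 3 and compound 1 cannot be told apart here, and of these three compounds only compound 2 stands apart. No supporting evidence is available to explain this difference. Open, as far as these compounds go, is how an unsubstituted amine or a dimethylamino group on this carbonyl carbon would compare with methylamino.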